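The source may report more compounds than this note shows. Statements on the series, on what has been measured and on what is new or still open speak of the compounds shown alone.

Measured in a functional assay on CCRF-CEM cells (Homo sapiens) for antiproliferative activity, read by cell counting, with a stated time of 72 h; on this read-out higher numbers stand for weaker inhibition and lower numbers for stronger inhibition:
- compound 1 `C#C[C@@]1(O)[C@@H](CO)O[C@@H](n2c(C(F)(F)F)cc3c(N)ncnc32)[C@@H]1O`: > 250000 nM
- compound 2 `C#Cc1cn([C@@H]2O[C@H](CO)[C@](O)(C#C)[C@H]2O)c2ncnc(N)c12`: 63000 nM
- compound 3 `C#C[C@@]1(O)[C@@H](CO)O[C@@H](n2cc(Cl)c3c(Cl)ccnc32)[C@@H]1O`: 1300 nM

The entry for compound 1 is a limit of the assay, not a number. Of the two actual numbers, compound 2 gives 63000 nM and compound 3 gives 1300 nM, a gap beyond the scatter, so compound 3 has the lowest number.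

Compound 4 `C#C[C@@]1(O)[C@@H](CO)O[C@@H](n2ccc3c(Cl)ccnc32)[C@@H]1O` has hydrogen in place of chloro on an aromatic carbon. Going by the values given here, no measured pair shows this change on its own. In this assay, a moderate step toward weaker inhibition, beyond the scatter, is expected. The expected step is a 3.8-fold higher number from compound 3 to compound 4 (0.59 log units; beyond the scatter). The estimate for compound 4 is 5000 nM, with an expected range of 1000 nM to 30000 nM.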

Compound 4, half-maximal inhibitory concentration: 86000 nM
The estimate for compound 4 lay 17-fold (1.24 log units) below the measured number; the whole stated range lies below it.
By their numbers in this assay, from the lowest: compound 3; then compounds 2 and 4 (each within the scatter of the next). At a limit, above all of these: compound 1.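

In this assay, hydrogen in place of chloro on an aromatic carbon of the five-membered aromatic ring gives a 66-fold higher number from compound 3 to compound 4 (1.82 log units; beyond the scatter), a large step. Going by these compounds alone, this is the first pair that differs in one place, and it shows that the low number of compound 3 depends on this chloro. Nothing shown gives a cause for the step.

Going by these compounds, whether bromo, methyl or an amine at this position would hold the number of compound 3 stays open. So does the contribution of the second chloro of compound 3.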